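Isopropylsulfanyl for dimethylamino: will cytotoxicity stay undetectable?

The compounds below may be only part of what the source reports. "The series", "measured", "known", "first", "only" and "open" are said of these compounds alone.

Three measured compounds share one core and differ only in the group on a single aromatic carbon. Compound 1 is `Nc1nc(OCC(F)(F)F)c2ncn(/C=C3/CC3(CO)CO)c2n1`, compound 2 is `CN(C)c1nc(N)nc2c1ncn2/C=C1/CC1(CO)CO`, and compound 3 is `CSc1nc(N)nc2c1ncn2/C=C1/CC1(CO)CO`. In an ADME assay on BCBL1 cells (Homo sapiens) for cytotoxicity, with a stated time of 7 days (a lower number here means that less compound is tolerated, a higher number that more compound is tolerated), compound 1 gives only the limit > 20000 nM, not a number. Compound 2 likewise gives only the limit > 20000 nM in this assay. Compound 3 also gives only the limit > 20000 nM in this assay. Compound 2 therefore stands exactly where every measured compound stands: the limit of > 20000 nM in this assay, at which 3 of the 3 values shown sit. The steps a step that the two limits leave unreadable from compound 1 to compound 2, a step that the two limits leave unreadable from compound 1 to compound 3 and a step that the two limits leave unreadable from compound 2 to compound 3 each run from one limit to another, so their size cannot be read.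

Compound 4, `CC(C)Sc1nc(N)nc2c1ncn2/C=C1/CC1(CO)CO`, has not yet been measured. It differs from compound 2 by isopropylsulfanyl in place of dimethylamino on an aromatic carbon. Every exchange of a small group at this carbon seen so far has left the compound at the limit of this assay, so the step that the limit leaves unreadable from compound 2 to compound 4 is expected to be none beyond the scatter, with another limit the most likely outcome. Compound 4 is accordingly estimated at 25000 nM, with a range from 8000 nM to 80000 nM.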

Compound 4, half-maximal cytotoxic concentration: > 20000 nM
Compound 4 was reported as a limit (the forecaster's own chance of this, stated with the estimate: 75%); the middle value is on the limit's open side.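

Compound 1, compound 2, compound 3 and compound 4 each give only a limit in this assay, so the steps from compound 4 to the other three cannot be read: the limit of > 20000 nM in this assay, at which 4 of the 4 values shown sit.

The compounds shown leave open at what concentration any of them would harm the cells in this assay, and whether the group on this aromatic carbon changes that concentration.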